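Aryl for cyclohexyl at the chain carbon of the anilide series

The compounds below may be only part of what the source reports. "The series", "measured", "known", "first", "only" and "open" are said of these compounds alone.

Measured so far:
compound 1 `CCC(C(=O)NCc1ccc(C(F)(F)F)nc1N1CCC(C)CC1)c1ccc(NS(C)(=O)=O)c(F)c1`: 1.6 nM
compound 2 `CC1CCN(c2nc(C(F)(F)F)ccc2CNC(=O)C(c2ccc(NS(C)(=O)=O)c(F)c2)C2CCCCC2)CC1`: 31.1 nM
compound 3 `CS(=O)(=O)Nc1ccc(C(C(=O)NCc2ccc(C(F)(F)F)nc2SC2CCCCC2)C2CCCCC2)cc1F`: "active" (no number reported)

In an assay on CHO cells for antagonist activity at transient receptor potential cation channel subfamily V member 1 (Homo sapiens), read by FLIPR (a lower number here means a stronger inhibitor, a higher number a weaker inhibitor), compound 1 gives 1.6 nM and compound 2 gives 31.1 nM; the step of a 19-fold higher number from compound 1 to compound 2 (1.29 log units; beyond the scatter) is the only measured one and it concerns the same saturated chain carbon. Compound 3 stands only as "active" (no number reported) in this assay, so no number anchors it. Compound 4 `Cc1ccccc1C(C(=O)NCc1ccc(C(F)(F)F)nc1SC1CCCCC1)c1ccc(NS(C)(=O)=O)c(F)c1` differs from compound 3 by 2-methylphenyl in place of cyclohexyl on a saturated chain carbon bound to an aromatic carbon and a carbonyl carbon. Among the compounds with values here, no measured step compares an aromatic ring with cyclohexyl at that carbon, so no direction beyond the scatter is expected in this assay; the expectation rests loosely on the cyclohexyl compound 2, which gives 31.1 nM. Compound 4 is estimated at 30 nM, with a range of 5 nM to 200 nM.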

Compound 4, inhibition constant: "active" (no number reported)
For compound 4 the study gives words and no number, so the estimate cannot be set against anything.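

In this assay compound 3 and compound 4 are both reported only as "active", so no step can be read between them, and no evidence bears on the result. As far as these compounds go, whether 2-methylphenyl in place of cyclohexyl on the saturated chain carbon raises or lowers the number stays open.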